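The source may hold more compounds than are shown below. What is called first, only, known or untested is meant among the compounds shown, and "the series" means these compounds.

In a functional assay on SH-SY5Y cells (Homo sapiens) for cytotoxicity, read by MTT assay, with a stated time of 72 h (on this read-out higher numbers stand for weaker inhibition and lower numbers for stronger inhibition), compound 1 `O=C1c2c[n+]([O-])c3ccccc3c2C(=O)c2c1c1ccccc1n2Cc1cn(CC(O)CO)nn1` reports only a limit, > 1000 nM. For the measured compounds named here, compound 2 `CN1CCN(CCCn2c3c(c4ccccc42)C(=O)c2c[n+]([O-])c4ccccc4c2C3=O)CC1` gives 560 nM, the only exact number so far. Compound 3 `CN1CCN(CCCCCCn2c3c(c4ccccc42)C(=O)c2c[n+]([O-])c4ccccc4c2C3=O)CC1` carries 3-(4-methylpiperazin-1-yl)propyl in place of 4-methylpiperazin-1-yl on a saturated chain carbon, three bonds along the chain from an aromatic nitrogen. Going by the values given here, the one measured step, an at least 1.7-fold lower number from compound 1 to compound 2 (0.25 log units; that floor lies within the scatter), changed a different group and depends on (the limit of > 1000 nM in this assay, at which 1 of the 2 values shown sits), so it offers only weak guidance here. No change beyond the scatter is expected, with an estimated 1.3-fold lower number from compound 2 to compound 3 (0.12 log units; within the scatter). Compound 3 is expected to give 420 nM, within an estimated range of 130 nM to 1300 nM.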

Compound 3, half-maximal inhibitory concentration: 920 nM
Compound 3: the middle estimate sits 2.2-fold (0.34 log units) below what was measured, within the range that was stated.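

In this assay, placing 3-(4-methylpiperazin-1-yl)propyl in place of 4-methylpiperazin-1-yl on a saturated chain carbon, three bonds along the chain from an aromatic nitrogen, gives a 1.6-fold higher number from compound 2 to compound 3 (0.22 log units; within the scatter), so this longer chain leaves the two compounds indistinguishable on this read-out. Compound 1 gives > 1000 nM, which is a limit and not a number. The step of an at least 1.0-fold lower number from compound 1 to compound 3 (0.03 log units; that floor lies within the scatter) therefore cannot be read as a size: the limit of > 1000 nM in this assay, at which 1 of the 3 values shown sits.

Still open, on these data alone, is how a chain of intermediate length would read. Also open, as far as these compounds go, is whether a morpholine or a dimethylamine at the chain end would read the same as the 4-methylpiperazin-1-yl group.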